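The source may report more compounds than this note shows. Statements on the series, on what has been measured and on what is new or still open speak of the compounds shown alone.

Measured in an ADME assay on BJ cells (Homo sapiens) for inhibition, with a stated time of 72 h; on this read-out lower numbers stand for an effect already at smaller amounts and higher numbers for an effect only at larger amounts of compound:
compound 1 `O=C(O)/C=C/C(=O)Nc1cccc(-c2nc3ccccc3s2)c1` — > 25000 nM
compound 2 `CC(Cl)C(=O)Nc1cccc(-c2nc3ccccc3s2)c1` — > 25000 nM
compound 3 `O=C(Nc1cccc(-c2nc3ccccc3s2)c1)c1ccnc(Cl)c1` — > 25000 nM

Every value in this set is a limit of the assay and not a number. For compound 1 the value > 25000 nM is such a limit. For compound 2 the value > 25000 nM is such a limit. For compound 3 the value > 25000 nM is such a limit; compound 3 therefore stands nowhere that can be placed against the others, all three sitting at the limit of > 25000 nM in this assay, at which 3 of the 3 values shown sit.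

The measured steps are accordingly unreadable: a step that the two limits leave unreadable from compound 1 to compound 2, a step that the two limits leave unreadable from compound 1 to compound 3 and a step that the two limits leave unreadable from compound 2 to compound 3. Changing the group on the carbonyl carbon from 2-carboxyethenyl to 1-chloroethyl or to 2-chloropyridin-4-yl has not moved any compound into the readable range.

Compound 4 `O=C(Nc1cccc(-c2nc3ccccc3s2)c1)c1ccncc1Cl` differs from compound 3 by 3-chloropyridin-4-yl in place of 2-chloropyridin-4-yl on a carbonyl carbon. Among the measured compounds shown here, no measured step bears on this change with a readable size; the three steps give only unreadable directions. The expectation is a step that the limit leaves unreadable from compound 3 to compound 4 from compound 3 to compound 4 that is not beyond the scatter, most likely again a limit. Compound 4 is estimated at 40000 nM, with a range from 12000 nM to 150000 nM.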

Compound 4, half-maximal effective concentration: > 25000 nM
Compound 4: only a limit was reported; the forecaster's own chance of this, stated with the estimate: 80%; the middle value is on the limit's open side.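

No new step can be read: in this assay compound 4 ends at the same limit of the assay as compound 1, compound 2 and compound 3, so its steps to all three remain unreadable: the limit of > 25000 nM in this assay, at which 4 of the 4 values shown sit. The compounds shown leave open how the four rank against one another and which group on the carbonyl carbon, if any, gives a readable value.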